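A few compounds are considered here, and "the series" means these few. Any claim that something is new, unique, unknown or untested is made for them only; others in the source may bear on it.

Working notes on the series. In a functional assay on A549 cells (Homo sapiens) for antiproliferative activity, read by MTT assay, with a stated time of 72 h (a lower number here means a stronger inhibitor, a higher number a weaker inhibitor), compound 1, `Cc1ccc(S(=O)(=O)NCc2cn(C[C@H](O)[C@H]3OC(=O)C(OCc4ccccc4)=C3OCc3ccccc3)nn2)cc1`, gives 16800 nM. For the measured compounds named here, compound 3, `O=C1O[C@H]([C@@H](O)Cn2cc(CNS(=O)(=O)c3ccc(Cl)cc3F)nn2)C(OCc2ccccc2)=C1OCc1ccccc1`, gives 39100 nM in this assay; the step of a 2.3-fold higher number from compound 1 to compound 3 (0.37 log units; beyond the scatter) is the only measured one-point change in the set. Compound 2, `Cc1ccc(-c2cn(C/C=C3\OC(=O)C(OCc4ccccc4)=C3OCc3ccccc3)nn2)cc1`, stands apart from both: in this assay compound 2 gives only a limit, > 100000 nM, so its place on the numbers is a bound and not a value. That bound is the limit of > 100000 nM in this assay, at which 1 of the 3 values shown sits.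

Compound 4, `O=C1O/C(=C\Cn2cc(-c3cccc(O)c3)nn2)C(OCc2ccccc2)=C1OCc1ccccc1`, is not yet measured. It differs from compound 2 by 3-hydroxyphenyl in place of 4-methylphenyl on an aromatic carbon. Going by the values given here, no measured step touches this part of the structure; the one measured step concerns a group on a sulfonyl sulfur in compounds 1 and 3, whose cores are not shared with compound 2, so it gives no direct guide. With compound 2 at a limit, the expected step of a number no higher from compound 2 to compound 4 (the limit leaves the size open) is estimated as small, most likely staying near or at the limit. The estimate for compound 4 in this assay is 100000 nM, within 30000 nM to 300000 nM.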

Compound 4, half-maximal inhibitory concentration: 23300 nM
For compound 4 the middle estimate is 4.3-fold (0.63 log units) above the measured one; the whole stated range lies above it.
By their numbers in this assay, from the lowest: compounds 1, 4 and 3 (each within the scatter of the next, the first and the last beyond it). At a limit, above all of these: compound 2.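

In this assay, replacing 4-methylphenyl with 3-hydroxyphenyl on an aromatic carbon of the five-membered aromatic ring with 3 nitrogen gives an at least 4.2-fold lower number from compound 2 to compound 4 (0.63 log units; beyond the scatter). The earlier step concerned only a group on a sulfonyl sulfur, whereas this one shows that the group at this position can move this core from a limit to a measured number. The full size of the step remains unknown because compound 2 stands at a limit: the limit of > 100000 nM in this assay, at which 1 of the 4 values shown sits.

The two phenyl groups differ both in the group they carry and in where it sits, and the compounds shown do not separate these two changes; 3-methylphenyl or 4-hydroxyphenyl would bear on that point. Going by these compounds, how an amine or a carboxylic acid on the phenyl ring would read at this position also remains open.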